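Swapping Bromo for Trifluoromethyl on the Five-Membered Ring

The compounds below may be only part of what the source reports. "The series", "measured", "known", "first", "only" and "open" are said of these compounds alone.

Compound 1 `C[C@@H]1CN(c2sc(C3CC3)nc2-c2nc3ccccc3[nH]2)CCN1C(=O)Cn1cnc2cccnc21` gives 9.7 nM in a functional assay on CHO-K1 cells for antagonist activity at C-X-C chemokine receptor type 3 (Homo sapiens), read by FLIPR, with a stated time of 10 min; on this read-out lower numbers stand for stronger inhibition and higher numbers for weaker inhibition.
Compound 2 `C[C@@H]1CN(c2sc(Br)nc2-c2nc3ccccc3[nH]2)CCN1C(=O)Cn1cnc2cccnc21` gives 2.8 nM in this assay.

For the measured compounds named here, compound 2 holds the lower of the two numbers measured so far. Compound 3 `C[C@@H]1CN(c2sc(C(F)(F)F)nc2-c2nc3ccccc3[nH]2)CCN1C(=O)Cn1cnc2cccnc21` differs from it by trifluoromethyl in place of bromo on an aromatic carbon. Going by the values given here, the only measured step at this position is a 3.5-fold lower number from compound 1 to compound 2 (0.54 log units; beyond the scatter), which shows that this position can move the number appreciably. Among the compounds with values here, no measured pair compares bromo with trifluoromethyl, so the direction remains uncertain. The expected step is a 1.8-fold higher number from compound 2 to compound 3 (0.25 log units; within the scatter), a small rise close to the scatter. Compound 3 is therefore estimated at 5 nM, with a range from 1.5 nM to 18 nM.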

Compound 3, half-maximal inhibitory concentration: 1.6 nM
Estimate against measurement, compound 3: 3.1-fold (0.49 log units) above; measured number inside the range.
By their numbers in this assay, from the lowest: compounds 3 and 2 (each within the scatter of the next); then compound 1.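

In this assay the change from bromo to trifluoromethyl on this aromatic carbon gives a 1.8-fold lower number from compound 2 to compound 3 (0.24 log units; within the scatter) and so does not separate the two groups. Trifluoromethyl in place of cyclopropyl gives a 6.1-fold lower number from compound 1 to compound 3 (0.78 log units; beyond the scatter) and, like bromo, stands clearly apart from cyclopropyl at this position. No measurement shown here accounts for this.

The compounds shown leave open how an amine, a methoxy group or a plain hydrogen on this carbon would read. They also leave open whether bromo and trifluoromethyl would remain inseparable on a different core.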